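A few compounds are considered here, and "the series" means these few. Any claim that something is new, unique, unknown or untested is made for them only; others in the source may bear on it.

Compound 1 `Cc1nc(N2CCN(C3CCCC3)CC2)nc2ccc(NC(=O)COc3ccc(Cl)cc3)cc12`: 96 nM. Compound 2 `Cc1nc(N2CCN(C)CC2)nc2ccc(NC(=O)COc3ccc(Cl)cc3)cc12`: 220 nM.

In an assay on CHO-K1 cells for displacement of a labelled ligand from melanin-concentrating hormone receptor 1 (Homo sapiens), with a stated time of 2 h (on this read-out higher numbers stand for weaker inhibition and lower numbers for stronger inhibition), compound 2 gives 220 nM, the higher of the two numbers, while compound 1 gives 96 nM. Among the compounds with values here, the only measured step, a 2.3-fold higher number from compound 1 to compound 2 (0.36 log units; beyond the scatter), concerns a change of the group on the amine nitrogen of the ring and nothing else. Compound 3 `CCC1(O)CCN(c2nc(C)c3cc(NC(=O)COc4ccc(Cl)cc4)ccc3n2)CC1` differs from compound 2 by 4-ethyl-4-hydroxypiperidin-1-yl in place of 4-methylpiperazin-1-yl on an aromatic carbon, an exchange of the whole ring rather than of a substituent on it, so the measured step bears on it only loosely: it shows that alterations in this part of compound 2 shift the number by a modest amount. Within the data shown here, no measured pair covers this exchange of one ring for another, so the direction rests on little. For compound 3 a modest rise in the number is expected, a 2.0-fold higher number from compound 2 to compound 3 (0.31 log units; beyond the scatter). For compound 3 the estimate is 450 nM, within a range from 110 nM to 2000 nM.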

Compound 3, half-maximal inhibitory concentration: 208 nM
Compound 3: the middle estimate sits 2.2-fold (0.34 log units) above what was measured; the measured number falls inside the stated range.
By their numbers in this assay, from the lowest: compound 1; then compounds 3 and 2 (each within the scatter of the next).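

In this assay, exchanging the whole ring on this aromatic carbon gives a 1.1-fold lower number from compound 2 to compound 3 (0.02 log units; within the scatter), so 4-ethyl-4-hydroxypiperidin-1-yl stands level with 4-methylpiperazin-1-yl, and for this pair the second ring nitrogen of the piperazine is not needed to hold the number. Against 4-cyclopentylpiperazin-1-yl, the same exchange gives a 2.2-fold higher number from compound 1 to compound 3 (0.34 log units; beyond the scatter), which leaves compound 1 with the lowest number of the three. No measurement is available to explain either result.

The compounds shown do not separate the contributions of the ethyl and the hydroxyl at the 4-position of the piperidine, which a 4-hydroxypiperidin-1-yl or a 4-ethylpiperidin-1-yl group would address. On these data alone, it also remains open whether a cyclopentyl on that same piperidine carbon would bring the number closer to that of compound 1.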